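From anilino to cyano: expectation for compound 3

The source may report more compounds than this note shows. Statements on the series, on what has been measured and on what is new or still open speak of the compounds shown alone.

Compound 1 `O=c1cc(Oc2ccccc2)c2ccc(OCc3cccc(Cl)c3)cc2o1` and compound 2 `O=c1cc(Nc2ccccc2)c2ccc(OCc3cccc(Cl)c3)cc2o1` share one core and differ only in the group on it. In an assay on isolated protein (strain Sprague-Dawley) for inhibition of Amine oxidase [flavin-containing] A (Rattus norvegicus), read by spectrophotometry, with a stated time of 5 min, tested at 10 uM (on this read-out higher numbers stand for more inhibition at the one concentration tested (going by the name of the read-out) and lower numbers for less inhibition), compound 1 gives 0%, and compound 2 gives 0%. Among the compounds with values here, the one measured step, no change at the digits printed from compound 1 to compound 2 (within the scatter), shows that exchanging these two groups left the read-out unchanged, so compound 2 stands level with compound 1 and neither shows any inhibition at the concentration tested.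

Compound 3 `N#Cc1cc(=O)oc2cc(OCc3cccc(Cl)c3)ccc12` is not yet measured. It differs from compound 2 as follows: cyano in place of anilino on an aromatic carbon. Within the data shown here, no measured step involves a cyano group, so the only guide is that the one known change on this carbon, no change at the digits printed from compound 1 to compound 2 (within the scatter), moved nothing. The expected step of a number 8 percentage points higher from compound 2 to compound 3 (within the scatter) is therefore small, with a slight chance of a rise, and compound 3 is estimated at 8%, within 0% to 30%.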

Compound 3, a percentage reported as inhibition, at one concentration (the size of the read-out at that concentration, not a potency): 23%
Compound 3: middle estimate off by 15 percentage points, on the low side; the range from low to high includes it.
By their numbers in this assay, from the lowest: compounds 1 and 2 (each within the scatter of the next); then compound 3.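

In this assay, cyano in place of anilino gives a number 23 percentage points higher from compound 2 to compound 3 (beyond the scatter), and cyano in place of phenoxy gives a number 23 percentage points higher from compound 1 to compound 3 (beyond the scatter), so the read-out at this aromatic carbon does respond to the group it carries. The exchange between phenoxy and anilino, both of which bring a six-membered aromatic ring, had shown no such response; cyano, which has no ring and far fewer heavy atoms, is the first group here to move the number beyond the scatter. Nothing measured here explains the rise.

These compounds leave open whether the gain follows from losing the aromatic ring or from the nitrile itself. A methyl group, a primary amine or a carboxylic acid on this carbon would help separate those two readings.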